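The source may hold more compounds than are shown below. What is called first, only, known or untested is meant among the compounds shown, and "the series" means these compounds.

Measured compounds:
- compound 1 `Cc1nc2ccccc2n1CCCCN1CCN(C(c2ccccc2)c2ccccc2)CC1`, 850 nM in an assay on RPMI-8226 cells for antagonist activity at P2X purinoceptor 7 (Homo sapiens), read by calcium flux; a lower number here means a stronger inhibitor, a higher number a weaker inhibitor
- compound 2 `Fc1ccc2c(ccn2CCCCN2CCN(C(c3ccccc3)c3ccccc3)CC2)c1`, 120 nM in this assay
- compound 3 `Fc1ccc2ccn(CCCCN3CCN(C(c4ccccc4)c4ccccc4)CC3)c2c1`, 110 nM in this assay

Compound 3 sits at the lowest of the three numbers, but the step of a 1.1-fold lower number from compound 2 to compound 3 (0.04 log units; within the scatter) lies within the scatter, so compounds 2 and 3 cannot be told apart. Both stand clearly apart from compound 1: a 7.1-fold lower number from compound 1 to compound 2 (0.85 log units; beyond the scatter) and a 7.7-fold lower number from compound 1 to compound 3 (0.89 log units; beyond the scatter).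

Compound 4 `Fc1cc2ccn(CCCCN3CCN(C(c4ccccc4)c4ccccc4)CC3)c2cc1F` is not yet measured. Relative to compound 3 the change is fluoro in place of hydrogen on an aromatic carbon, on an aromatic carbon of a six-membered aromatic ring of carbon only, part of a fused system of two rings. For the measured compounds named here, the only measured step that touches this ring position is the one from compound 2 to compound 3, which moved the single fluoro and changed nothing beyond the scatter. Going by the values given here, no measured pair shows a second fluoro entering. For compound 4 in this assay the expected step is therefore small, a 1.1-fold lower number from compound 3 to compound 4 (0.04 log units; within the scatter), with no clear direction. The estimate for compound 4 is 100 nM, within 40 nM to 250 nM.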

Compound 4, half-maximal inhibitory concentration: 130 nM
Beside the measured number, compound 4's estimate is 1.3-fold (0.11 log units) below it; the measured number falls inside the stated range.
By their numbers in this assay, from the lowest: compounds 3, 2 and 4 (each within the scatter of the next); then compound 1.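

In this assay, a second fluoro entering ortho to a fluoro group leaves the number unresolved from those of the singly fluorinated compounds: a 1.2-fold higher number from compound 3 to compound 4 (0.07 log units; within the scatter) and a 1.1-fold higher number from compound 2 to compound 4 (0.03 log units; within the scatter) are the two readings. This aromatic carbon therefore accepts a fluoro in place of hydrogen with no readable change, which the earlier move of the single fluoro could not show. The separation from the 2-methyl-1H-benzimidazol-1-yl compound also persists with two fluoro groups, as a 6.5-fold lower number from compound 1 to compound 4 (0.82 log units; beyond the scatter) shows, and nothing at hand gives a cause for either result.

On these data alone, whether chloro, methoxy or nitrile at this carbon would keep the number equally flat remains open. Also open, as far as these compounds go, is what the same chain and shared core give with hydrogen alone on this ring.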